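The source may report more compounds than this note shows. Statements on the series, on what has been measured and on what is new or still open speak of the compounds shown alone.

Measured so far:
- compound 1 `C=COc1cc(N2CCCNCC2)cnc1Br`: 0.646 nM
- compound 2 `Brc1ccc(N2CCCNCCC2)cn1`: 0.447 nM
- compound 3 `Clc1cncc(N2CCNCC2)c1`: 309 nM

In an assay on HEK293 cells for displacement of a labelled ligand from Neuronal acetylcholine receptor; alpha4/beta2 (Homo sapiens) (on this read-out lower numbers stand for stronger inhibition and higher numbers for weaker inhibition), compound 1 gives 0.646 nM, the second highest of the three numbers. Compound 2 lies nearest, at 0.447 nM, within the scatter of compound 1, so no order between these two is claimed. Compound 3, at 309 nM, lies far above both, beyond the scatter; it differs from compound 1 in more than one place, so that gap cannot be tied to any single change.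

Compound 4 `C=COc1cncc(N2CCCNCC2)c1` has not been measured. Its difference from compound 1 is hydrogen in place of bromo on an aromatic carbon, in words: hydrogen in place of bromo on an aromatic carbon. For the measured compounds named here, no pair of measured compounds shows this step alone. Going by the values given here, both compounds that carry bromo, compound 1 and compound 2, sit at the low end of the numbers, while the only compound without it, compound 3, sits high, though with other differences as well. On that basis a step upward in this assay is expected from compound 1 to compound 4, estimated at a 9.3-fold higher number from compound 1 to compound 4 (0.97 log units; beyond the scatter), with wide uncertainty. Compound 4 is therefore expected near 6 nM, in the range 1 nM to 40 nM.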

Compound 4, half-maximal inhibitory concentration: 5.01 nM
The estimate for compound 4 lay 1.2-fold (0.08 log units) above the measured number; the measured number falls inside the stated range.
By their numbers in this assay, from the lowest: compounds 2 and 1 (each within the scatter of the next); then compound 4; then compound 3.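

For the compounds shown here, replacing bromo with hydrogen on the aromatic carbon next to the ring nitrogen, ortho to a vinyloxy group, gives the first single-place comparison: in this assay it produces a 7.8-fold higher number from compound 1 to compound 4 (0.89 log units; beyond the scatter). The link between bromo and low numbers therefore no longer rests only on compounds that differ in several places, and without bromo compound 4 still gives 5.01 nM, so the loss at this position is modest. Nothing available explains the size of this step.

Still open, going by these compounds, is how fluoro, methyl or an amine at this position would compare with bromo and hydrogen. On these data alone, it is also open whether the same step would appear with a longer chain in place of the vinyloxy group, or with a different amine ring on the shared core.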